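The compounds below may be only part of what the source reports. "The series", "measured", "known", "first", "only" and "open" are said of these compounds alone.

Measured so far in a functional assay on SK-BR-3 cells (Homo sapiens) for antiproliferative activity, read by MTT assay, with a stated time of 72 h; on this read-out higher numbers stand for weaker inhibition and lower numbers for stronger inhibition:
compound 1, `Cc1cc(NCCN2CCN(C)CC2)nc2ccc(NC(=O)c3ccc(Cl)c(Cl)c3)cc12`: compound 1 gives 2690 nM
compound 2, `CCc1ccccc1C(=O)Nc1ccc2nc(N3CCN(CC)CC3)cc(C)c2c1`: compound 2 gives 23900 nM
compound 3, `CCN1CCN(c2cc(C)c3cc(NC(=O)c4ccco4)ccc3n2)CC1`: compound 3 gives 37500 nM

Compound 1 gives the lowest of the three numbers; compound 2 and compound 3 both stand higher, and both gaps from compound 1 are beyond the scatter. For the measured compounds named here, the only single-point step among the measured compounds, a 1.6-fold higher number from compound 2 to compound 3 (0.20 log units; within the scatter), alters the group on the carbonyl carbon and stays within the scatter.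

Compound 4, `Cc1cc(NCCN2CCCC2)nc2ccc(NC(=O)c3ccc(Cl)c(Cl)c3)cc12`, differs from compound 1 by pyrrolidin-1-yl in place of 4-methylpiperazin-1-yl on a saturated chain carbon, two bonds along the chain from a nitrogen on an aromatic ring. Going by the values given here, no measured step touches the amine at the end of the chain, so none bears on this change, and the series gives no ground to expect a step beyond the scatter; the expected step is a 1.0-fold higher number from compound 1 to compound 4 (0.00 log units; within the scatter). Compound 4 is therefore estimated at 2700 nM, within a range of 1000 nM to 8000 nM.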

Compound 4, half-maximal inhibitory concentration in the SK-BR-3 assay: 9530 nM
Estimate against measurement, compound 4: 3.5-fold (0.55 log units) below; measured number outside the range, above it.
By their numbers in the SK-BR-3 assay, from the lowest: compound 1; then compound 4; then compounds 2 and 3 (each within the scatter of the next).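

In the SK-BR-3 assay the amine at the end of the chain carries weight: the change to pyrrolidin-1-yl gives a 3.5-fold higher number from compound 1 to compound 4 (0.55 log units; beyond the scatter) and so, unlike the earlier step on the carbonyl carbon, lies beyond the scatter. In a physicochemical assay for lipophilicity, at pH 7.4 (on this read-out higher numbers stand for higher lipophilicity and lower numbers for lower lipophilicity), compound 1 gives 1.73 and compound 4 gives 1.72 and the two stand within the scatter, so this read-out does not separate them. No measured evidence accounts for the step in antiproliferative activity.

As far as these compounds go, whether a morpholine, a piperidine or a dimethylamino group at the chain end would track compound 1 or compound 4 remains open. A longer chain is equally untested here.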